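The source may report more compounds than this note shows. Statements on the series, on what has been measured and on what is new or still open speak of the compounds shown alone.

The study compares four ester derivatives of two related cores in a functional assay on MCF7 cells (Homo sapiens) for antiproliferative activity, read by MTT assay, with a stated time of 72 h; on this read-out lower numbers stand for stronger inhibition and higher numbers for weaker inhibition. Compound 1 `CC1=CC[C@H]2[C@H](CC[C@]2(C)O)C(C)(C)[C@@H]1CC[C@H]1[C@]2(C)CC[C@H](OC(=O)c3ccncc3)C(C)(C)O[C@H]2CC[C@@]1(C)O` carries a pyridin-4-yl group on the carbonyl carbon, and compound 2 `CC1=CC[C@H]2[C@H](CC[C@]2(C)O)C(C)(C)[C@@H]1CC[C@H]1[C@]2(C)CC[C@H](OC(=O)c3ccc(C)cc3)C(C)(C)O[C@H]2CC[C@@]1(C)O` differs from it only by 4-methylphenyl in place of pyridin-4-yl on a carbonyl carbon. In this assay compound 1 gives 25300 nM. Compound 2 reaches only a limit of the assay, reported as > 50000 nM. The step from one to the other is an at least 1.9-fold higher number from compound 1 to compound 2 (0.29 log units; that floor lies within the scatter), and that floor lies within the usual scatter, so the direction of the change cannot be fixed from this pair alone; what is clear is that compound 2 sits at the limit of > 50000 nM in this assay, at which 2 of the 3 values shown sit.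

Compound 3 `CC1=CC[C@H]2[C@@H]1CC=C(C)[C@@H](CC[C@H]1[C@]3(C)CC[C@H](OC(=O)c4ccncc4)C(C)(C)O[C@H]3CC[C@@]1(C)O)C2(C)C` carries the same pyridin-4-yl ester on a different core; how the core of compound 3 differs from the core of compound 1 is not broken down here. In this assay compound 3 also reaches only a limit, reported as > 50000 nM.

Compound 4 `CC1=CC[C@H]2[C@@H]1CC=C(C)[C@@H](CC[C@H]1[C@]3(C)CC[C@H](OC(=O)c4ccc(C)cc4)C(C)(C)O[C@H]3CC[C@@]1(C)O)C2(C)C` stands to compound 3 as compound 2 stands to compound 1: it differs by 4-methylphenyl in place of pyridin-4-yl on a carbonyl carbon, the same change at the same place. Compound 4 has not been measured in this assay. Given that compound 3 already sits at the limit, and that the same change on the other core gave the step of an at least 1.9-fold higher number from compound 1 to compound 2 (0.29 log units; that floor lies within the scatter), compound 4 is expected to remain at or beyond that limit. Compound 4 is estimated at 90000 nM, a range of 40000 nM to 250000 nM. The step this estimate means, a step that the limit leaves unreadable from compound 3 to compound 4, is expected to be no more than a modest one, with the result most likely reported only as a limit.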

Compound 4, half-maximal inhibitory concentration: > 50000 nM
Compound 4 was reported as a limit; the forecaster's own chance of this, stated with the estimate: 85%; the middle value does not contradict the limit.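

Compound 3 and compound 4 are both reported only as limits in this assay, so no step can be read from compound 3 to compound 4: the limit of > 50000 nM in this assay, at which 3 of the 4 values shown sit.

The compounds shown leave open what values lie behind these limits, and so whether 4-methylphenyl in place of pyridin-4-yl on a carbonyl carbon changes the read-out on either core, and in which direction.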